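A few compounds are considered here, and "the series" means these few. Any claim that something is new, unique, unknown or untested is made for them only; others in the source may bear on it.

Measured so far in a functional assay on MCF7 cells (Homo sapiens) for antiproliferative activity, read by sulforhodamine B assay, with a stated time of 48 h; a lower number here means a stronger inhibitor, a higher number a weaker inhibitor:
- Compound 1 `CCCN1CCN(c2ccc(S(=O)(=O)Oc3ccccc3C)cc2)C1=O`: > 100000 nM (a limit)
- Compound 2 `CCCN1CCN(c2ccc(S(=O)(=O)Oc3c(Cl)cc(Cl)cc3Cl)cc2)C1=O`: > 100000 nM (a limit)

In this assay, compound 2 gives > 100000 nM, which is a limit of the assay and not a number. The same holds for compound 1, and the whole record so far is the limit of > 100000 nM in this assay, at which 2 of the 2 values shown sit. The next compound, compound 3 `CCCN1CCN(c2ccc(S(=O)(=O)Oc3cccc(C)c3)cc2)C1=O`, has 3-methylphenyl in place of 2,4,6-trichlorophenyl on an oxygen whose other neighbour is the sulfonyl sulfur: 3-methylphenyl in place of 2,4,6-trichlorophenyl on an oxygen.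

Among the compounds with values here, only one measured step bears on this change: a step that the two limits leave unreadable from compound 1 to compound 2. It exchanged 2-methylphenyl for 2,4,6-trichlorophenyl at the same oxygen, so its size offers no guide. Compound 1 also carries a methylphenyl group there, and it gives > 100000 nM, again a limit. With no readable step to draw on, no shift beyond the scatter is expected in either direction, and a further limit is the likeliest result. The expected step is a number no higher from compound 2 to compound 3 (the limit leaves the size open). For compound 3 the estimated value is 100000 nM, with an expected range from 30000 nM to 150000 nM.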

Compound 3, half-maximal inhibitory concentration: 86000 nM
Compound 3: the middle estimate sits 1.2-fold (0.07 log units) above what was measured; the measured number falls inside the stated range.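

In this assay, within the data shown here, compound 3 gives 86000 nM, the only value shown that is a number and not a limit of the assay. At the oxygen whose other neighbour is the sulfonyl sulfur, 3-methylphenyl in place of 2,4,6-trichlorophenyl gives an at least 1.1-fold lower number from compound 2 to compound 3 (0.06 log units; that floor lies within the scatter), and 3-methylphenyl in place of 2-methylphenyl gives an at least 1.1-fold lower number from compound 1 to compound 3 (0.06 log units; that floor lies within the scatter). Both steps are floors that lie within the scatter, so neither change is shown to be a real gain, and the record at this position remains dominated by the limit: the limit of > 100000 nM in this assay, at which 2 of the 3 values shown sit.

The step between the other two compounds still cannot be read, as both of its ends are limits. From the compounds shown here alone, whether a phenyl group carrying an amine or a carboxylic acid on this oxygen would give a number clearly away from the limit stays open, as does the effect of a longer chain on the shared core.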